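This account rests on a few compounds, and the source may have more. Where it says the series, first, only, none or still open, it means among the compounds named here.

Compound 2 `CC(C)=CCC[C@]1(C)/C=C/[C@@H](OC(=O)C=C(C)C)[C@](C)(O)/C=C/C(=O)/C(CN2CCCC2)=C\C1` sits at the low end of the three numbers in hand. In a functional assay on A549 cells (Homo sapiens) for antiproliferative activity, read by MTT assay, with a stated time of 48 h (on this read-out higher numbers stand for weaker inhibition and lower numbers for stronger inhibition), compound 2 gives 180 nM, while compound 3 `CC(C)=CCC[C@]1(C)/C=C/[C@@H](OC(=O)C=C(C)C)[C@](C)(O)/C=C/C(=O)/C(COC(=O)c2ccc([N+](=O)[O-])cc2)=C\C1` gives 1310 nM and compound 1 `COC/C1=C/C[C@](C)(CCC=C(C)C)/C=C/[C@@H](OC(=O)C=C(C)C)[C@](C)(OC)/C=C/C1=O` gives 4180 nM. Going by the values given here, the one step between neighbours, a 7.3-fold higher number from compound 2 to compound 3 (0.86 log units; beyond the scatter), shows what happens when the pyrrolidin-1-yl group is exchanged for ((4-nitrophenyl)carbonyl)oxy on the same saturated chain carbon.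

Compound 4 `CCN(CC)C(=O)/C1=C/C[C@](C)(CCC=C(C)C)/C=C/[C@@H](OC(=O)C=C(C)C)[C@](C)(O)/C=C/C1=O` differs from compound 2 by diethylcarbamoyl in place of (pyrrolidin-1-yl)methyl on a double-bonded ring carbon. The step from compound 2 to compound 3 bears most on this change, since it also removes the pyrrolidin-1-yl group from that position, and the weaker number of compound 1 points the same way. The author therefore expects a step of similar size and direction, an 8.3-fold higher number from compound 2 to compound 4 (0.92 log units; beyond the scatter), upward rather than downward. The estimate for compound 4 in this assay is 1500 nM, with a range from 500 nM to 5000 nM.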

Compound 4, half-maximal inhibitory concentration: 11300 nM
The estimate for compound 4 lay 7.5-fold (0.88 log units) below the measured number; measured number above the stated range.
By their numbers in this assay, from the lowest: compound 2; then compound 3; then compound 1; then compound 4.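

In this assay, exchanging (pyrrolidin-1-yl)methyl for diethylcarbamoyl on the double-bonded ring carbon gives a 63-fold higher number from compound 2 to compound 4 (1.80 log units; beyond the scatter), a large step, whereas the earlier change on the saturated chain carbon gave only a modest one, a 7.3-fold higher number from compound 2 to compound 3 (0.86 log units; beyond the scatter). The low number of compound 2 therefore does not carry over to every group holding a nitrogen and five carbons at this position, since diethylcarbamoyl has those too and still loses most of the inhibition. No measurement is at hand that accounts for this loss.

This single change removes the ring and also puts a carbonyl where the saturated chain carbon stood, so the two remain unseparated. A (diethylamino)methyl group or a (pyrrolidin-1-yl)carbonyl group on this carbon would tell them apart.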